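Two-furyl quinoxaline ureas tested against a mitochondrial chaperone

The source may report more compounds than this note shows. Statements on the series, on what has been measured and on what is new or still open speak of the compounds shown alone.

This account concerns two measured compounds and one that awaits measurement in an assay on cells for inhibition of HSP60/HSP10 (Homo sapiens), with a stated time of 60 min; a higher number here means a weaker inhibitor, a lower number a stronger inhibitor. Compound 1, `CNC(=O)Nc1ccc2nc(-c3ccco3)c(-c3ccco3)nc2c1`, gives 7400 nM in this assay. Compound 2, `O=c1c([N+](=O)[O-])c(Cl)c2ccccc2n1Cc1ccccc1`, gives 2800 nM, so compound 1 stands with the highest of the two numbers, and its gap to compound 2 lies beyond the usual scatter of repeated measurements. Going by the values given here, the two compounds share no common core, so what their values show is only that compound 1 is the weaker of the pair.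

Compound 3, `O=C(Nc1ccc2nc(-c3ccco3)c(-c3ccco3)nc2c1)N1CCCC1`, is drawn from compound 1 by a single change: pyrrolidin-1-yl in place of methylamino on a carbonyl carbon. Among the compounds with values here, the shared core of compounds 1 and 3 is untouched, and no measured pair of this kind exists here to show what such a change does. With nothing to lean on but the value of compound 1, the author expects compound 3 to stay close to it, with a step of a 1.2-fold higher number from compound 1 to compound 3 (0.09 log units; within the scatter) that is most likely within the scatter, or at most a modest move toward a higher number. The estimate for compound 3 is therefore 9000 nM, with a range from 3000 nM to 27000 nM.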

Compound 3, half-maximal inhibitory concentration: 13000 nM
Estimate against measurement, compound 3: 1.4-fold (0.16 log units) below; measured number inside the range.
By their numbers in this assay, from the lowest: compound 2; then compounds 1 and 3 (each within the scatter of the next).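

In this assay, going by these compounds alone, the change reads as a 1.8-fold higher number from compound 1 to compound 3 (0.24 log units; within the scatter), which gives the first measured step at this place, on a carbonyl carbon whose other neighbour is an amide-type nitrogen. Pyrrolidin-1-yl brings 5 heavy atoms and a five-membered non-aromatic ring and has no hydrogen-bond donor, whereas methylamino has 2 heavy atoms and 1 hydrogen-bond donor, yet compound 1 and compound 3 cannot be told apart in this read-out. In this single pair, then, the exchange of these two groups leaves no difference beyond the scatter, and nothing measured here bears on why that is so.

From the compounds shown here alone, it remains open whether dimethylamino on the same carbonyl carbon, which has no ring, would also stay level with compound 1, and whether a piperidin-1-yl or morpholin-4-yl group would do the same as pyrrolidin-1-yl. Going by these compounds, what a change elsewhere on the shared core would do is also open, since compound 1 and compound 3 differ in one place only.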